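This account rests on a few compounds, and the source may have more. Where it says the series, first, only, none or still open, it means among the compounds named here.

Three compounds that share one core and differ only in the length of one chain have been measured so far in a functional assay (brain) for inhibition, with Rattus norvegicus as the target (on this read-out higher numbers stand for weaker inhibition and lower numbers for stronger inhibition), on the same footing. Compound 1 (`CCCCCCCCCOC1=C(O)OC(C(O)CO)C1=O`) gives 0.027 nM there, compound 2 (`CCCCCCCCCCCOC1=C(O)OC(C(O)CO)C1=O`) gives 13000 nM there, and compound 3 (`CCCCCCCCCCCCCOC1=C(O)OC(C(O)CO)C1=O`) gives 7400 nM there. Compound 3 therefore sits level with compound 2 and far from compound 1, the strongest of the three. Large steps lead away from compound 1, a 480000-fold higher number from compound 1 to compound 2 (5.68 log units; beyond the scatter) and a 270000-fold higher number from compound 1 to compound 3 (5.44 log units; beyond the scatter) as well, whereas the further chain change shows only a 1.8-fold lower number from compound 2 to compound 3 (0.24 log units; within the scatter) and so stays within the scatter.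

Compound 4 (`CCCCCCCCCCCCCCOC1=C(O)OC(C(O)CO)C1=O`) alters compound 3 in one place, with methyl in place of hydrogen on a saturated chain carbon, ten or more bonds along the chain from an oxygen on an unsaturated carbon as the whole difference. This falls in the same stretch of the chain as the step from compound 2 to compound 3, which makes that step the closest guide. The large steps from compound 1 were changes nine bonds along the chain instead. Among the compounds with values here, only one step covers this stretch, so the guide is thin, and no step beyond the scatter is expected in either direction in this assay for this change. The expected result is a 1.1-fold higher number from compound 3 to compound 4 (0.03 log units; within the scatter) with no clear direction. The estimated value for compound 4 is 8000 nM with an expected range of 2500 nM to 25000 nM on this read-out.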

Compound 4, half-maximal inhibitory concentration: 7400 nM
Compound 4: middle estimate off by 1.1-fold (0.03 log units), on the high side; low and high end bracket the measured number.
By their numbers in this assay, from the lowest: compound 1; then compounds 3, 4 and 2 (each within the scatter of the next).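

In this assay, a methyl in place of hydrogen on a saturated chain carbon, ten or more bonds along the chain from an oxygen on an unsaturated carbon, leaves the read-out as it was (no change at the digits printed from compound 3 to compound 4 (within the scatter)). The larger propyl change in the same stretch also stays small (a 1.8-fold lower number from compound 2 to compound 4 (0.24 log units; within the scatter)), so compound 2, compound 3 and compound 4 now form a flat stretch of three chain lengths, where before there was a single step to go on, while the large gap to the shortest chain holds (a 270000-fold higher number from compound 1 to compound 4 (5.44 log units; beyond the scatter)). Nothing available explains either this flat stretch or the large gap to compound 1.

On these data alone, what a methyl at the place nine bonds along the chain would give remains open, and such a compound would help show where, between compound 1 and compound 2, the large step sets in. As far as these compounds go, it is also open whether a longer chain, or a chain carrying a carboxylic acid or an amine, would stay in the flat stretch or leave it.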